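The source may report more compounds than this note shows. Statements on the series, on what has been measured and on what is new or still open speak of the compounds shown alone.

Compound 1, with the structure `COc1cc(-c2nnc3n2NC(c2ccco2)C(C(=O)c2ccc(Cl)cc2)S3)cc(OC)c1OC`, belongs to a small set of three measured compounds that share one core and differ in the aryl group attached to the carbonyl carbon and in the five-membered ring at the carbon next to the amine. In a functional assay on MCF7 cells (Homo sapiens) for cytotoxicity, read by MTT assay, with a stated time of 48 h (on this read-out lower numbers stand for stronger inhibition and higher numbers for weaker inhibition), compound 1 gives only a limit of the assay, > 100000 nM, and no number. Compound 2, `COc1cc(C(=O)C2Sc3nnc(-c4cc(OC)c(OC)c(OC)c4)n3NC2c2cccs2)cc(OC)c1OC`, gives 71000 nM in this assay, and compound 3, `COc1ccc(C(=O)C2Sc3nnc(-c4cc(OC)c(OC)c(OC)c4)n3NC2c2cccs2)cc1`, gives 49500 nM. Going by the values given here, the one measured step, a 1.4-fold lower number from compound 2 to compound 3 (0.16 log units; within the scatter), concerns the aryl group on the carbonyl carbon and shows no change beyond the scatter.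

Compound 4, `COc1cc(-c2nnc3n2NC(c2ccco2)C(C(=O)c2ccc(C(F)(F)F)cc2)S3)cc(OC)c1OC`, has not been measured. It differs from compound 1 in one place: trifluoromethyl in place of chloro on an aromatic carbon. This change also sits on the aryl group of the carbonyl carbon, so the step from compound 2 to compound 3 is the closest guide, and it was flat. Because compound 1 sits at the limit of > 100000 nM in this assay, at which 1 of the 3 values shown sits, the starting point is itself only a limit.

The estimate for compound 4 is therefore 100000 nM, with a range from 40000 nM to 250000 nM. This estimate amounts to an expected step of a number no higher from compound 1 to compound 4 (the limit leaves the size open), and a limit rather than a number is judged the more likely outcome.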

Compound 4, half-maximal inhibitory concentration: 33600 nM
Compound 4: the middle estimate sits 3.0-fold (0.47 log units) above what was measured; measured number outside the range, below it.
By their numbers in this assay, from the lowest: compounds 4, 3 and 2 (each within the scatter of the next, the first and the last beyond it). At a limit, above all of these: compound 1.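

Putting trifluoromethyl in place of chloro on the aromatic carbon of the aryl group attached to the carbonyl gives a clear change in this assay, namely an at least 2.9-fold lower number from compound 1 to compound 4 (0.47 log units; beyond the scatter). Going by these compounds alone, the earlier compounds showed only a step within the scatter on this aryl group, so this is the first sign that the group can change the read-out when everything else in the molecule stays the same. The printed step is only a lower bound on the true size of the change, because compound 1 carries a limit and not a number: the limit of > 100000 nM in this assay, at which 1 of the 4 values shown sits.

As far as these compounds go, with only chloro and trifluoromethyl compared at this place, it remains open whether a fluoro atom, a methyl group, a nitrile, an amine or a carboxylic acid would give a number like that of compound 4 or one nearer the limit of compound 1. Within the data shown here, it also remains open whether the same exchange would give a similar step with the other five-membered ring, the one carried by compound 2 and compound 3.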